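Fluoro in place of methyl on the phenyl ring

The compounds below may be only part of what the source reports. "The series", "measured", "known", "first", "only" and "open" are said of these compounds alone.

Compound 2 `Cc1cccc(-n2cc(-c3cccc(NS(=O)(=O)c4c[nH]c(=O)[nH]c4=O)c3)nn2)c1` gives 3550 nM in a functional assay on A549 cells (Homo sapiens) for antiproliferative activity, read by MTT assay, with a stated time of 24 h (a higher number here means a weaker inhibitor, a lower number a stronger inhibitor), the lower of the two numbers shown. Compound 1 `Cc1ccccc1-n1cc(-c2cccc(NS(=O)(=O)c3c[nH]c(=O)[nH]c3=O)c2)nn1` gives 5470 nM in this assay, and the step of a 1.5-fold lower number from compound 1 to compound 2 (0.19 log units; within the scatter) is within the scatter. Compound 3 `O=c1[nH]cc(S(=O)(=O)Nc2cccc(-c3cn(-c4cccc(F)c4)nn3)c2)c(=O)[nH]1` differs from compound 2 by fluoro in place of methyl on an aromatic carbon. Among the compounds with values here, the only measured step concerns the same ring and stayed within the scatter, so the change from compound 2 to compound 3 is expected to give a 1.1-fold higher number from compound 2 to compound 3 (0.05 log units; within the scatter), nothing beyond the scatter. Compound 3 is thus estimated at 4000 nM, with a range from 1500 nM to 11000 nM.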

Compound 3, half-maximal inhibitory concentration: 7200 nM
Compound 3: the middle estimate sits 1.8-fold (0.26 log units) below what was measured; measured number inside the range.
By their numbers in this assay, from the lowest: compounds 2, 1 and 3 (each within the scatter of the next, the first and the last beyond it).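

In this assay, within the data shown here, the change from 3-methylphenyl to 3-fluorophenyl gives the first step on this ring that passes the scatter, though only modestly (a 2.0-fold higher number from compound 2 to compound 3 (0.31 log units; beyond the scatter)). Set against the 2-methylphenyl group, the 3-fluorophenyl group stays within the scatter (a 1.3-fold higher number from compound 1 to compound 3 (0.12 log units; within the scatter)), so the position and the group cannot be separated by these compounds alone. Nothing measured here bears on this result.

As far as these compounds go, it remains open how a chloro, methoxy or amine group on the same ring carbon would compare with compound 2. From the compounds shown here alone, it is also open whether fluoro would read differently on the ring carbon that holds the methyl group of compound 1.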